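The source may hold more compounds than are shown below. What is called first, only, known or untested is meant among the compounds shown, and "the series" means these compounds.

Compound 1 `COc1ccc(-c2csc(N3N=C(c4ccc(F)cc4)CC3c3ccc4c(c3)OCCO4)n2)cc1` gives 4430 nM in a functional assay on B16-F10 cells (Mus musculus) for antiproliferative activity, read by MTT assay, with a stated time of 48 h; a higher number here means a weaker inhibitor, a lower number a stronger inhibitor; compound 2 `Clc1ccc(C2=NN(c3nc(-c4ccc(Br)cc4)cs3)C(c3ccc4c(c3)OCCO4)C2)cc1` gives 2150 nM in this assay.

Compound 2 carries the lower of the two numbers, and the gap to compound 1 lies beyond the scatter. Among the compounds with values here, compound 3 `COc1ccc(-c2csc(N3N=C(c4ccc(Cl)cc4)CC3c3ccc4c(c3)OCCO4)n2)cc1` differs from compound 2 by methoxy in place of bromo on an aromatic carbon; compound 1 shares this methoxy but differs elsewhere, so no single step is known for it. Compound 3 is expected to move toward the number of compound 1, a step of a 1.4-fold higher number from compound 2 to compound 3 (0.16 log units; within the scatter) in the weaker direction. Compound 3 is estimated at 3100 nM, within 1500 nM to 6500 nM.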

Compound 3, half-maximal inhibitory concentration: 3120 nM
Compound 3: the middle estimate sits 1.0-fold (0.00 log units) below what was measured; the range from low to high includes it.
By their numbers in this assay, from the lowest: compounds 2, 3 and 1 (each within the scatter of the next, the first and the last beyond it).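

In this assay, within the data shown here, the change from 4-bromophenyl to 4-methoxyphenyl gives the first single-place step (a 1.5-fold higher number from compound 2 to compound 3 (0.16 log units; within the scatter)), and chloro in place of fluoro on an aromatic carbon gives the second (a 1.4-fold lower number from compound 1 to compound 3 (0.15 log units; within the scatter)). Each step stays within the scatter, so neither change, taken alone, is separated by this read-out. Nothing shown here bears on the reason for this. The compounds shown leave open whether an amine or a carboxylic acid on that aromatic carbon would give a step beyond the scatter.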